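Sugar exchange on the triazole arm of compound 2

The source may hold more compounds than are shown below. What is called first, only, known or untested is meant among the compounds shown, and "the series" means these compounds.

The series shares one core, seen in compound 1 `CN(C)CCCCCn1c2c(c3ccccc31)C(=O)c1c[n+]([O-])c3ccccc3c1C2=O`, which in a toxicity assay on HEK-293T cells (Homo sapiens) for cytotoxicity, read by MTT assay, with a stated time of 72 h (a higher number here means a weaker inhibitor, a lower number a stronger inhibitor), gives 70 nM. Compound 3 `CN1CCN(CCCn2c3c(c4ccccc42)C(=O)c2c[n+]([O-])c4ccccc4c2C3=O)CC1` gives 170 nM in this assay. Going by the values given here, the single measured one-point step, a 2.4-fold higher number from compound 1 to compound 3 (0.39 log units; beyond the scatter), concerns the amine-bearing chain and nothing else. Compound 2 `O=C1c2c[n+]([O-])c3ccccc3c2C(=O)c2c1c1ccccc1n2Cc1cn([C@H]2O[C@H](CO)[C@@H](O)[C@H]2O)nn1` gives 1370 nM in this assay and stands highest of the three numbers, separated beyond the scatter from compound 3 and, further still, from compound 1.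

Compound 4 `O=C1c2c[n+]([O-])c3ccccc3c2C(=O)c2c1c1ccccc1n2Cc1cn([C@@H]2O[C@H](CO)[C@@H](O)[C@H](O)[C@H]2O)nn1` is not yet measured. It differs from compound 2 as follows: 3,4,5-trihydroxy-6-(hydroxymethyl)oxan-2-yl in place of 3,4-dihydroxy-5-(hydroxymethyl)oxolan-2-yl on an aromatic nitrogen. The exchange sits on an aromatic nitrogen of a five-membered aromatic ring with 3 nitrogen, far from the chain varied between compound 1 and compound 3.

Among the compounds with values here, no measured step touches this position, so the step from compound 1 to compound 3 gives no direct guidance, and no sugar-to-sugar comparison exists among the measured compounds. The expectation is therefore a step for compound 4 of a 1.1-fold higher number from compound 2 to compound 4 (0.04 log units; within the scatter), not beyond the scatter. For compound 4 the estimated value in this assay is 1500 nM, with a range from 600 nM to 4000 nM.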

Compound 4, half-maximal inhibitory concentration: 940 nM
Beside the measured number, compound 4's estimate is 1.6-fold (0.20 log units) above it, and the stated range covers the measured number.
By their numbers in this assay, from the lowest: compound 1; then compound 3; then compounds 4 and 2 (each within the scatter of the next).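

Working notes on the sugar position: in this assay, the exchange of 3,4-dihydroxy-5-(hydroxymethyl)oxolan-2-yl for 3,4,5-trihydroxy-6-(hydroxymethyl)oxan-2-yl gives a 1.5-fold lower number from compound 2 to compound 4 (0.16 log units; within the scatter), so this assay does not separate the two sugars. Going by these compounds alone, this is the first reading at this position, on an aromatic nitrogen of a five-membered aromatic ring with 3 nitrogen, and it shows that going from a five-membered to a six-membered non-aromatic ring, with the added hydrogen-bond donor and acceptor counted for the entering group, leaves the number within the usual scatter, whereas the earlier step concerned only the amine-bearing chain. Nothing available explains this result or ties it to any feature of either sugar.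

Open, going by these compounds, is whether the sugar contributes to the number at all, a question that a carboxylic acid, a dimethylamino group or a plain methyl group at the same nitrogen would address. Also open, on these data alone, is whether the insensitivity extends to a sugar of different stereochemistry on the same six-membered ring, or to an acetylated sugar in which the hydroxyl groups are capped.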